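The source may report more compounds than this note shows. Statements on the series, on what has been measured and on what is new or still open speak of the compounds shown alone.

Compound 1 `CCCC(=O)Nc1cccc(NC(=O)COc2ccc3c(=O)ccoc3c2)c1` gives 176 nM in an assay on isolated protein for inhibition of Rho-associated protein kinase 2 (Homo sapiens), read by scintillation counting, radiometric assay and 33P incorporation, with a stated time of 40 min, in the presence of a further agent that is not named here; a higher number here means a weaker inhibitor, a lower number a stronger inhibitor.
Compound 2 `CC(C)(C)c1cc(C(=O)Nc2cccc(NC(=O)COc3ccc4c(=O)ccoc4c3)c2)no1` gives 5 nM in this assay.
Compound 3 `O=C(COc1ccc2c(=O)ccoc2c1)Nc1cccc(NC(=O)c2cnc(C(F)(F)F)s2)c1` has not yet been measured in this assay.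

Compound 2 stands at the lowest number of the two measured compounds. Among the measured compounds shown here, the single measured step, a 35-fold lower number from compound 1 to compound 2 (1.55 log units; beyond the scatter), is large and beyond the scatter, so the group on this carbonyl carbon matters a great deal. Compound 3 differs from compound 2 only at that place: 2-(trifluoromethyl)-1,3-thiazol-5-yl in place of 5-(tert-butyl)-1,2-oxazol-3-yl on a carbonyl carbon. For the measured compounds named here, the one step that bears on this change shows what happened when propyl was replaced by an aromatic ring; it does not show what one such ring against another does. Because compound 2 already gives 5 nM, the expected step of a 2.0-fold higher number from compound 2 to compound 3 (0.30 log units; within the scatter) is small, at most a drift toward a higher number. Compound 3 is therefore estimated at 10 nM, with a range from 3 nM to 40 nM.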

Compound 3, half-maximal inhibitory concentration: 10 nM
Compound 3: the middle estimate sits on the measured number at the digits printed; the measured number falls inside the stated range.
By their numbers in this assay, from the lowest: compounds 2 and 3 (each within the scatter of the next); then compound 1.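

In this assay, the step of a 2.0-fold higher number from compound 2 to compound 3 (0.30 log units; within the scatter) shows that 2-(trifluoromethyl)-1,3-thiazol-5-yl can take the place of 5-(tert-butyl)-1,2-oxazol-3-yl on this carbonyl carbon with no difference that can be told from the scatter. The step of an 18-fold lower number from compound 1 to compound 3 (1.25 log units; beyond the scatter) is also large, so the lower number relative to propyl, earlier seen with a single group, now holds for two different five-membered aromatic rings. No measurement is available that accounts for this result.

The compounds shown leave open whether a ring of this kind is needed at all, since a plain tert-butyl, a cyclohexyl or a phenyl group on this carbonyl carbon does not appear among them. They also leave open what the trifluoromethyl and tert-butyl groups each contribute, as neither ring appears without its group.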